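A few compounds are considered here, and "the series" means these few. Any claim that something is new, unique, unknown or untested is made for them only; others in the source may bear on it.

Measured in a functional assay on HCT-116 cells (Homo sapiens) for cytotoxicity, read by MTT assay, with a stated time of 3 days; on this read-out lower numbers stand for stronger inhibition and higher numbers for weaker inhibition:

- Compound 1 `CC(C)(C)c1cc2c(N/N=C/c3ccc4c(c3)CNCC4)ncnc2s1`: 0.107 ug/mL
- Compound 2 `CNCc1ccc(/C=N/Nc2ncnc3sc(C(C)(C)C)cc23)cc1`: 0.056 ug/mL

These two values lie within the usual scatter of repeated measurements, so the pair cannot be ranked. Compound 2 therefore stands level with compound 1, and both sit at small numbers on this scale.

The next compound to be tested is compound 3 `CN(C)S(=O)(=O)c1ccc(/C=N/Nc2ncnc3sc(C(C)(C)C)cc23)cc1`, which keeps the shared core of compound 2. The change is dimethylsulfamoyl in place of (methylamino)methyl on an aromatic carbon.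

Going by the values given here, both measured compounds carry an amine and compound 3 does not, and no measured compound shows what losing it does. Any forecast is therefore rough. With compound 2 already at 0.056 ug/mL, a swap of this size seems more likely to raise the number than to lower it. A moderate step towards weaker inhibition in this assay, beyond the scatter, is expected, estimated as a 7.1-fold higher number from compound 2 to compound 3 (0.85 log units; beyond the scatter). For compound 3 the estimated value is 0.4 ug/mL, with an expected range from 0.08 ug/mL to 2 ug/mL.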

Compound 3, half-maximal inhibitory concentration: 1.42 ug/mL
The estimate for compound 3 lay 3.6-fold (0.55 log units) below the measured number, within the range that was stated.
By their numbers in this assay, from the lowest: compounds 2 and 1 (each within the scatter of the next); then compound 3.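

In this assay, going by these compounds alone, placing dimethylsulfamoyl where (methylamino)methyl stood gives a 25-fold higher number from compound 2 to compound 3 (1.40 log units; beyond the scatter), a large change and the first measured step between compounds that differ in one place. It shows that the group on this aromatic carbon, para to a large group, can strongly shift the number while the shared core stays the same, and that this particular swap moves it towards weaker inhibition. The swap changes several things at once, since the entering group has more heavy atoms, brings in sulfur and oxygen, and has no hydrogen-bond donor, and no measurement here links the step to any of these differences or gives a reason for it.

The compounds shown leave open whether the amine nitrogen itself matters, which a simple dimethylaminomethyl or hydroxymethyl group at the same place could begin to test. They also leave open whether the loss comes from the sulfonyl unit or from its two methyl groups, a question that an unsubstituted sulfamoyl group or a methylsulfonyl group would address.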